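Hydroxy to methoxy: one untested step in the series

This account rests on a few compounds, and the source may have more. Where it says the series, first, only, none or still open, it means among the compounds named here.

Of the compounds shown here, two on a shared core have been measured. Compound 1 `C=C1CC[C@H]2C(C)(C)CCC[C@]2(C)[C@H]1C[C@@H](O)C1=CCOC1=O` and compound 2 `C=C1CC[C@H]2C(C)(C)CCC[C@]2(C)[C@H]1C/C=C1\CC(O)OC1=O` differ in more than one place, so only their two values are compared. In a functional assay on RAW264.7 cells (Mus musculus) for inhibition, read by ELISA, with stated times of 1 h and 18 h, tested at 5 uM (on this read-out lower numbers stand for a stronger effect and higher numbers for a weaker effect at the one concentration tested), compound 1 gives 75.6%. Compound 2 gives 64% in this assay, the lower of the two numbers; its nearest neighbour is compound 1, whose number is higher by a margin beyond the usual scatter.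

Compound 3 `C=C1CC[C@H]2C(C)(C)CCC[C@]2(C)[C@H]1C/C=C1\CC(OC)OC1=O` differs from compound 2 in one change: methyl in place of hydrogen on an oxygen on a saturated carbon; cut one bond further out, this reads hydroxy to methoxy. Among the compounds with values here, no measured pair shows this change, so its size cannot be read from the data. Compound 3 is expected to show a step of a number 1 percentage points lower from compound 2 to compound 3 (within the scatter) of no clear direction and not beyond the scatter. The estimate for compound 3 in this assay is 63%, within a range from 46% to 80%.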

Compound 3, a percentage reported as activity, at one concentration (the size of the read-out at that concentration, not a potency): 70%
Compound 3: the middle estimate sits 7 percentage points below what was measured, within the range that was stated.
By their numbers in this assay, from the lowest: compounds 2, 3 and 1 (each within the scatter of the next, the first and the last beyond it).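

Methyl in place of hydrogen on an oxygen on a saturated carbon now has a measured size: in this assay the pair gives a number 6 percentage points higher from compound 2 to compound 3 (within the scatter). On this single pair, hydroxy to methoxy at this position leaves the read-out at the one concentration tested not separable from that of compound 2, so the free hydroxy hydrogen is not required to keep a read-out in this range. No measurement shown bears on why the two compounds read alike.

Still open, on these data alone, is how this position responds to a larger change, such as a longer chain on this oxygen or an amine in its place. As far as these compounds go, the read-out comes from a single concentration, so how compound 2 and compound 3 compare at any other concentration also remains unknown.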